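The compounds below may be only part of what the source reports. "The series", "measured", "known", "first", "only" and "open" are said of these compounds alone.

Working notes on the series, read in an ADME assay on NIH3T3 cells (Mus musculus) for cytotoxicity, with a stated time of 72 h; a higher number here means a weaker inhibitor, a lower number a stronger inhibitor. Compound 1 `OC[C@H]1O[C@@H](n2cnc3c(NCc4ccccc4F)ncnc32)[C@H](O)[C@@H]1O` returns only a limit, > 166000 nM. Compound 2 `OC[C@H]1O[C@@H](n2cnc3c(NCc4ccc(F)cc4)ncnc32)[C@H](O)[C@@H]1O` gives a measured number, 44300 nM. Compound 3 `OC[C@H]1O[C@@H](n2cnc3c(NCc4cccc(Br)c4)ncnc32)[C@H](O)[C@@H]1O` also returns only a limit, > 166000 nM. Compound 3 therefore has no number of its own and stands at the limit of > 166000 nM in this assay, at which 2 of the 3 values shown sit.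

The next structure is compound 4 `Cc1cccc(CNc2ncnc3c2ncn3[C@@H]2O[C@H](CO)[C@@H](O)[C@H]2O)c1`, with methyl in place of bromo on an aromatic carbon, meta to a large group: methyl in place of bromo on an aromatic carbon.

Within the data shown here, no measured step makes this exchange. The nearest steps swap the substituted phenyl group. 4-Fluorophenyl in place of 2-fluorophenyl gives an at least 3.7-fold lower number from compound 1 to compound 2 (0.57 log units; beyond the scatter). 3-Bromophenyl in place of 4-fluorophenyl gives an at least 3.7-fold higher number from compound 2 to compound 3 (0.57 log units; beyond the scatter). 3-Bromophenyl in place of 2-fluorophenyl gives a step that the two limits leave unreadable from compound 1 to compound 3. Only compound 2 carries a number, so the series offers a single reading away from the limit.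

The new substituent keeps the place it has in compound 3, so no step beyond the scatter is expected in this assay, and no direction can be assigned. A fall toward compound 2 stays possible given an at least 3.7-fold higher number from compound 2 to compound 3 (0.57 log units; beyond the scatter). The expected change is an at least 1.3-fold lower number from compound 3 to compound 4 (0.14 log units; that floor lies within the scatter). The expected value for compound 4 is 120000 nM, with an estimated range of 40000 nM to 250000 nM.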

Compound 4, half-maximal inhibitory concentration: > 166000 nM
Compound 4: no number, only a limit; the forecaster's own chance of this, stated with the estimate: 50%; at least 1.3-fold (0.14 log units) between middle value and limit.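

In this assay, among these compounds, the aromatic carbon meta to a large group now holds two different substituents, bromo in compound 3 and methyl in compound 4, and neither gives a measured number. 3-Methylphenyl in place of 4-fluorophenyl gives an at least 3.7-fold higher number from compound 2 to compound 4 (0.57 log units; beyond the scatter), so this second substituent at that place also stands clear of the only measured compound, compound 2. The steps from compound 3 to compound 4 and from compound 1 to compound 4 cannot be read, since both ends of each are limits, and the exchange of bromo for methyl therefore has no size, while the series now rests mostly on one reading: the limit of > 166000 nM in this assay, at which 3 of the 4 values shown sit.

The compounds shown leave open whether an amine, a carboxylic acid or a methoxy group on the same aromatic carbon would bring a measured number in this assay. They also leave open whether the number of compound 2 follows from the place of its substituent or from fluoro itself, as a 4-methylphenyl or 4-bromophenyl group would help to tell.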